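The source may report more compounds than this note shows. Statements on the series, on what has been measured and on what is new or still open speak of the compounds shown alone.

Working notes on the series. The single read-out in hand is an ADME assay on microsomes from liver (Rattus norvegicus) for metabolic stability, read by LC-MS, using NADPH, with stated times of 5 min and 30 min, tested at 1 uM; on this read-out lower numbers stand for a less stable compound and higher numbers for a more stable compound. Compound 1 `O=C(O)c1ccc(-n2cc(C(=O)c3c(Cl)cccc3Cl)c3cccnc32)cc1` gives 100% in this assay. Within the data shown here, compound 2 `O=C(O)c1ccc(-n2cc(C(=O)c3c(Cl)cccc3Cl)c3cccnc32)c(F)c1` gives 90% in this assay; the only measured step, fluoro in place of hydrogen on an aromatic carbon, reads a number 10 percentage points lower from compound 1 to compound 2 (within the scatter). Compound 3 `O=C(O)c1ccc(-n2cc(C(=O)c3c(Cl)cccc3Cl)c3ccncc32)cc1` has "not determined" (no result reported) in this assay, so it contributes no number. On the numbers shown, compound 2 stands as the lower of the two figures, with compound 1 its nearest entry, the gap between them inside the scatter, so no order between the two is claimed.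

The next compound is compound 4 `Cc1cccc(Cl)c1C(=O)c1cn(-c2ccc(C(=O)O)cc2F)c2ncccc12`. Its difference from compound 2 is methyl in place of chloro on an aromatic carbon. Among the measured compounds shown here, no measured step bears on this part of the molecule: the one step in hand, a number 10 percentage points lower from compound 1 to compound 2 (within the scatter), concerns a different change and was itself within the scatter. The two measured numbers both sit high, and nothing in the data points to a step beyond the scatter in this assay for the chloro-to-methyl exchange, though the range is kept wide for lack of a precedent. Compound 4 is therefore expected at 85%, with a range from 60% to 100%. The step this estimate implies is a number 5 percentage points lower from compound 2 to compound 4 (within the scatter).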

Compound 4, percent of the compound remaining in the Rattus norvegicus assay: 73%
Compound 4: the middle estimate sits 12 percentage points above what was measured; measured number inside the range.
By their numbers in the Rattus norvegicus assay, from the lowest: compound 4; then compounds 2 and 1 (each within the scatter of the next).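

Among these compounds, in the Rattus norvegicus assay, the change from 2,6-dichlorophenyl to 2-chloro-6-methylphenyl gives a number 17 percentage points lower from compound 2 to compound 4 (beyond the scatter), so this position, on an aromatic carbon ortho to a large group, is the first place where a single exchange moves the read-out past the scatter, unlike the earlier fluoro step, although the size of the step is modest. In a physicochemical assay for solubility, at pH 7.4 (a lower number here means a less soluble compound, a higher number a more soluble compound), compound 2 reads > 2000000 nM, which is a limit of the assay and not a number. In the physicochemical assay compound 4 reads 1960000 nM. Against that limit, the physicochemical assay offers only an at least 1.0-fold lower number from compound 2 to compound 4 (0.00 log units; that floor lies within the scatter), and no order in solubility is claimed for this pair: the limit of > 2000000 nM in the physicochemical assay, at which 1 of the 2 values shown sits.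

The compounds shown leave open whether methoxy or trifluoromethyl in place of this chloro would read like methyl in the Rattus norvegicus assay, and whether exchanging the remaining chloro group would take the number further in the same direction. They also leave open whether the chloro-to-methyl exchange gives a step of similar size without the fluoro group, and how an amide in place of the carboxylic acid would read.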